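The compounds below may be only part of what the source reports. "The series", "measured", "known", "first", "only" and "open" are said of these compounds alone.

Compound 3, `Cc1cc(COc2cc(C)nn2C2CCCC2)n(-c2ccccc2)n1`, is one of three analogues sharing a core in which one ring nitrogen carries a variable group. In a physicochemical assay for acid dissociation, tested at 10 mM, compound 3 gives 2.7. Compound 1, `Cc1cc(COc2cc(C)nn2-c2ccccc2)n(-c2ccccc2)n1`, gives 2.7, and compound 2, `Cc1cc(COc2cc(C)nn2-c2ccc([N+](=O)[O-])cc2)n(-c2ccccc2)n1`, gives 2. Compound 3 thus stands level with compound 1 at the digits printed, the two together being the highest of the three numbers, while compound 2 lies furthest away.

The step from compound 3 to compound 4, `Cc1cc(OCc2cc(C)nn2-c2ccccc2)n(CC(=O)O)n1`, is carboxymethyl in place of cyclopentyl on an aromatic nitrogen. The measured steps that bear on this position are no change at the digits printed from compound 1 to compound 3 (within the scatter) and a number 0.70 log units higher from compound 2 to compound 3 (beyond the scatter). Within the data shown here, the only change that moved this assay beyond the scatter was a number 0.70 log units lower from compound 1 to compound 2 (beyond the scatter), a nitro group on an aromatic carbon; swapping phenyl for cyclopentyl on the aromatic nitrogen left the number unchanged. Among the measured compounds shown here, no measured step introduces a carboxymethyl group, so the size of the coming step is uncertain, and compound 4 carries a hydrogen-bond donor that none of the measured compounds has. Compound 4 is therefore expected to read near or somewhat above compound 3, with an estimated step of a number 0.40 log units higher from compound 3 to compound 4 (beyond the scatter). The estimate for compound 4 is 3.1, within a range from 2.3 to 3.9.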

Compound 4, acid dissociation constant: 7.3
The estimate for compound 4 lay 4.20 log units below the measured number; the whole stated range lies below it.
By their numbers in this assay, from the lowest: compound 2; then compounds 1 and 3 (each within the scatter of the next); then compound 4.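

In this assay, among these compounds, the group on this aromatic nitrogen turns out to be able to shift the number far more than the earlier compounds showed: replacing phenyl with cyclopentyl gave no change at the digits printed from compound 1 to compound 3 (within the scatter), whereas carboxymethyl in place of cyclopentyl gave a number 4.60 log units higher from compound 3 to compound 4 (beyond the scatter). The same carboxymethyl group in place of phenyl gave a number 4.60 log units higher from compound 1 to compound 4 (beyond the scatter) and in place of 4-nitrophenyl gave a number 5.30 log units higher from compound 2 to compound 4 (beyond the scatter), so all three ring-bearing groups on this nitrogen read lower than the ringless carboxymethyl group, and each of these steps is much larger than the one nitro substitution, a number 0.70 log units lower from compound 1 to compound 2 (beyond the scatter). Nothing measured here accounts for the size of these steps.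

The compounds shown leave open whether this large step needs the whole carboxymethyl group or only part of it, which a methyl ester, an amide or a longer chain ending in a carboxylic acid on the same nitrogen would help to separate. Among the compounds shown here, they also leave open how an amine at this position would read, since carboxymethyl is the only group without a ring that appears there.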